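From compound 1 to the 3-iodophenyl compound 4

A few compounds are considered here, and "the series" means these few. Any claim that something is new, unique, unknown or untested is made for them only; others in the source may bear on it.

- compound 1 `COc1ccccc1OS(=O)(=O)c1ccc(N2CCN(C)C2=O)cc1`: 26000 nM
- compound 2 `Cc1cccc(OS(=O)(=O)c2ccc(N3CCN(C)C3=O)cc2)c1`: 5100 nM
- compound 3 `CN1CCN(c2ccc(S(=O)(=O)Oc3cccc(F)c3)cc2)C1=O`: > 100000 nM (a limit)

In a functional assay on MCF7 cells (Homo sapiens) for antiproliferative activity, read by sulforhodamine B assay, with a stated time of 48 h (a lower number here means a stronger inhibitor, a higher number a weaker inhibitor), compound 1 gives 26000 nM, the higher of the two actual numbers, and compound 2 gives 5100 nM. Compound 3 reports > 100000 nM, which is a limit of the assay and not a number.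

The next change leads to compound 4 `CN1CCN(c2ccc(S(=O)(=O)Oc3cccc(I)c3)cc2)C1=O`, with 3-iodophenyl in place of 2-methoxyphenyl on an oxygen. Two measured steps make a similar exchange. The 3-methylphenyl exchange gave a 5.1-fold lower number from compound 1 to compound 2 (0.71 log units; beyond the scatter), a modest step. The 3-fluorophenyl exchange gave an at least 3.8-fold higher number from compound 1 to compound 3 (0.58 log units; beyond the scatter), at least modest and in the opposite direction. The large at least 19-fold higher number from compound 2 to compound 3 (1.29 log units; beyond the scatter) shows how far apart these two outcomes lie. Within the data shown here, no iodo compound has been measured, so the direction is uncertain, and the expectation leans only tentatively towards the result for compound 2. In this assay the expected change is a modest one, a 2.9-fold lower number from compound 1 to compound 4 (0.46 log units; beyond the scatter). For compound 4 the estimate is 9000 nM, with an expected range of 2000 nM to 50000 nM.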

Compound 4, half-maximal inhibitory concentration: 560 nM
Compound 4: middle estimate off by 16-fold (1.21 log units), on the high side; the whole stated range lies above it.
By their numbers in this assay, from the lowest: compound 4; then compound 2; then compound 1. At a limit, above all of these: compound 3.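

In this assay, 3-iodophenyl in place of 2-methoxyphenyl on an oxygen gives a 46-fold lower number from compound 1 to compound 4 (1.67 log units; beyond the scatter), so this place can carry a far larger gain than the 3-methylphenyl group suggested. Iodo in place of methyl gives a 9.1-fold lower number from compound 2 to compound 4 (0.96 log units; beyond the scatter), and iodo in place of fluoro gives an at least 170-fold lower number from compound 3 to compound 4 (2.25 log units; beyond the scatter), which puts the two halogens at opposite ends of the series. Compound 3 stands at a limit, so the last step is a bound only: the limit of > 100000 nM in this assay, at which 1 of the 4 values shown sits.

The exchange from compound 1 alters both the substituent and where it sits on the phenyl group, and the two contributions cannot be separated here. Also open, on these data alone, is how a chloro or bromo group would read in place of iodo, and whether the series would keep its gain with an amine there.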